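This account rests on a few compounds, and the source may have more. Where it says the series, first, only, none or still open, it means among the compounds named here.

Compound 1, `CC1CC1C(=O)N1CCc2nc(C#Cc3ccccc3)sc2C1`: 9.4 nM
Compound 2, `O=C(CC1CCOCC1)N1CCc2nc(C#Cc3ccccc3)sc2C1`: 470 nM
Compound 3, `N#Cc1cccc(C(=O)N2CCc3nc(C#Cc4ccccc4)sc3C2)c1`: 71 nM

These three compounds share one core and were all tested in an assay on HEK293 cells for positive allosteric modulation of metabotropic glutamate receptor 5 (Homo sapiens), read by FLIPR, with a stated time of 1 h; on this read-out higher numbers stand for an effect only at larger amounts of compound and lower numbers for an effect already at smaller amounts. Compound 1 gives the lowest number of the three; the nearest of the other two comes with a 7.6-fold higher number from compound 1 to compound 3 (0.88 log units; beyond the scatter), and the furthest with a 50-fold higher number from compound 1 to compound 2 (1.70 log units; beyond the scatter). Compound 4, `O=S(=O)(C1CC1)N1CCc2nc(C#Cc3ccccc3)sc2C1`, has not yet been measured. It differs from compound 1 in one place: cyclopropylsulfonyl in place of (2-methylcyclopropyl)carbonyl on an amine nitrogen in a ring.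

Going by the values given here, no measured step exchanges the carbonyl itself. The two steps that start from compound 1, a 50-fold higher number from compound 1 to compound 2 (1.70 log units; beyond the scatter) and a 7.6-fold higher number from compound 1 to compound 3 (0.88 log units; beyond the scatter), both replace the 2-methylcyclopropyl on the carbonyl carbon, and both raise the number, one modestly and one by a large amount. Every change so far made at this position has moved the number up from compound 1. A change that also exchanges the carbonyl for a sulfonyl is expected to do the same, with a step upward beyond the scatter, most likely nearer the modest end than the large one.

The expected value for compound 4 in this assay is 100 nM, with a range from 25 nM to 500 nM. This estimate means an expected step of an 11-fold higher number from compound 1 to compound 4 (1.03 log units; beyond the scatter).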

Compound 4, half-maximal effective concentration: > 10000 nM
Compound 4: no number, only a limit; the forecaster's own chance of this, stated with the estimate: 5%; middle value at least 100-fold (2.00 log units) away from the limit.
By their numbers in this assay, from the lowest: compound 1; then compound 3; then compound 2. At a limit, above all of these: compound 4.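

In this assay, compound 4 gives no number, only a limit of the assay: the limit of > 10000 nM in this assay, at which 1 of the 4 values shown sits. Even so, the result is an at least 1000-fold higher number from compound 1 to compound 4 (3.02 log units; beyond the scatter), which already goes further than the largest step among the earlier compounds, a 50-fold higher number from compound 1 to compound 2 (1.70 log units; beyond the scatter). Those earlier compounds all kept the carbonyl and varied only the group on its carbon, so compound 4 adds something new: cyclopropylsulfonyl in place of (2-methylcyclopropyl)carbonyl on the amine nitrogen in a ring moves the read-out further than any of those exchanges, even though both groups hold a three-membered ring of carbon only and the same number of heavy atoms.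

This single step exchanges the carbonyl for a sulfonyl and also removes the methyl from the three-membered ring, and with no cyclopropylcarbonyl group among the compounds shown, the share of each change cannot be separated. Going by these compounds, it also stays open how far beyond the limit compound 4 lies, and whether a sulfonyl carrying a phenyl ring or a longer chain in place of the cyclopropyl would behave the same way.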